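From 2-(4-fluorophenyl)ethynyl to 2,4-difluorophenyl

The source may hold more compounds than are shown below. What is called first, only, known or untested is meant among the compounds shown, and "the series" means these compounds.

For the measured compounds named here, in a functional assay on HCT-116 cells (Homo sapiens) for antiproliferative activity, with a stated time of 72 h (on this read-out higher numbers stand for weaker inhibition and lower numbers for stronger inhibition), compound 1 (`CCCCC#Cc1cc([C@@H]2O[C@H](CO)[C@@H](O)[C@H]2O)n2ncnc(N)c12`) gives 2900 nM and is the only compound here with a measured number. Compound 2 (`Nc1ncnn2c([C@@H]3O[C@H](CO)[C@@H](O)[C@H]3O)cc(C#Cc3ccc(F)cc3)c12`) gives > 100000 nM in this assay and this is a limit of the assay, not a number. Going by the values given here, the one measured step, 4-fluorophenyl in place of butyl on a triple-bonded carbon, is an at least 34-fold higher number from compound 1 to compound 2 (1.53 log units; beyond the scatter) and it is the only step that bears on what follows.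

Compound 3 (`Nc1ncnn2c([C@@H]3O[C@H](CO)[C@@H](O)[C@H]3O)cc(-c3ccc(F)cc3F)c12`) carries 2,4-difluorophenyl in place of 2-(4-fluorophenyl)ethynyl on an aromatic carbon. It keeps one six-membered aromatic ring of carbon only, the kind of group that came in with an at least 34-fold higher number from compound 1 to compound 2 (1.53 log units; beyond the scatter) and it loses the triple bond. Among the compounds with values here, no measured step tests that loss directly, so the evidence is thin. A modest move toward stronger inhibition is expected, and compound 3 may well remain at the limit. The expected size of an at least 3.3-fold lower number from compound 2 to compound 3 (0.52 log units; beyond the scatter) is only an estimate. The estimate for compound 3 is 30000 nM with 3000 nM to 100000 nM as its expected range.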

Compound 3, half-maximal inhibitory concentration: 59500 nM
For compound 3 the middle estimate is 2.0-fold (0.30 log units) below the measured one; low and high end bracket the measured number.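

With 2,4-difluorophenyl on this aromatic carbon, this assay gives a measured number for a six-membered aromatic ring of carbon only at this place, and the change from hex-1-yn-1-yl is a 21-fold higher number from compound 1 to compound 3 (1.31 log units; beyond the scatter), so both ring-bearing groups shown, with or without a triple bond, give weaker inhibition than the chain. Exchanging 2-(4-fluorophenyl)ethynyl for the directly attached ring gives an at least 1.6-fold lower number from compound 2 to compound 3 (0.22 log units; that floor lies within the scatter), so loss of the triple bond in this ring series cannot be claimed to bring a real gain, and a larger one cannot be excluded either. This step can be read only as a floor, because compound 2 stands at a limit of the assay: the limit of > 100000 nM in this assay, at which 1 of the 3 values shown sits.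

How far the ring itself, rather than its fluorine atoms, accounts for the distance from the chain stays open, and a plain phenyl group would bear on that. Equally open, going by these compounds, is whether the triple bond matters within the chain series, which a saturated hexyl chain would address, and how a butyl chain ending in an amine would behave at this position.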